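Amide substituent swap on the shared core

This account rests on a few compounds, and the source may have more. Where it says the series, first, only, none or still open, it means among the compounds named here.

Compound 1 `CN1CCC(NC(=O)c2ccc(Cn3nc(-c4cnn(C)c4)c4ccccc4c3=O)cc2)CC1` is the anchor of the series. In a functional assay on HeLa cells (Homo sapiens) for antiproliferative activity, read by MTT assay, with a stated time of 72 h (on this read-out lower numbers stand for stronger inhibition and higher numbers for weaker inhibition), compound 1 gives 28500 nM, the only number shown. For the measured compounds named here, the one further value shown, that of compound 2, is a limit. Compound 2 `Cc1noc(C)c1-c1nn(Cc2ccc(C(=O)NC3CCN(C)CC3)cc2)c(=O)c2ccccc12` carries 3,5-dimethyl-1,2-oxazol-4-yl in place of 1-methyl-1H-pyrazol-4-yl on an aromatic carbon. In this assay compound 2 reaches only a limit, > 100000 nM. Going by the values given here, the step of an at least 3.5-fold higher number from compound 1 to compound 2 (0.54 log units; beyond the scatter) is the only measured step, and it sits at the limit of > 100000 nM in this assay, at which 1 of the 2 values shown sits.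

Compound 3 `Cn1cc(-c2nn(Cc3ccc(C(=O)NC4CC(C)(C)N([O])C(C)(C)C4)cc3)c(=O)c3ccccc23)cn1` is not yet measured. It differs from compound 1 by a group of 11 heavy atoms (9 carbon, 1 nitrogen, 1 oxygen; one six-membered non-aromatic ring with 1 hetero atom) in place of a group of 7 heavy atoms (6 carbon, 1 nitrogen; one six-membered non-aromatic ring with 1 hetero atom), on an amide-type nitrogen. Among the compounds with values here, that is a change on the amide-type nitrogen, whereas the one measured step concerns the aromatic carbon, so no measured step bears on this change. Its size is at least modest, but it gives no guidance for the amide side of the molecule.

With nothing to go on, compound 3 is expected to move no further than the scatter, and the step of a 1.2-fold higher number from compound 1 to compound 3 (0.09 log units; within the scatter) is the estimate. For compound 3 the estimated value in this assay is 35000 nM, with a range from 10000 nM to 100000 nM.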

Compound 3, half-maximal inhibitory concentration: 27700 nM
Beside the measured number, compound 3's estimate is 1.3-fold (0.10 log units) above it; the measured number falls inside the stated range.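

Notes on the amide side: with 1-methylpiperidin-4-yl on the amide-type nitrogen replaced by the group of 11 heavy atoms, this assay gives a 1.0-fold lower number from compound 1 to compound 3 (0.01 log units; within the scatter) as the step, so the two values stand within the scatter of each other. For the compounds shown here, this is the first reading on this position, as the earlier step concerned only the aromatic carbon, and it shows that the larger group, which also has one six-membered non-aromatic ring with 1 hetero atom, can be carried here without a step beyond the scatter. Nothing measured in the series offers a cause for this result.

Still open, on these data alone, is whether an open-chain group such as 2-(dimethylamino)ethyl, or a group ending in a carboxylic acid, would also remain within the scatter of compound 1 on the amide-type nitrogen. Also open, as far as these compounds go, is how 3,5-dimethyl-1,2-oxazol-4-yl on the aromatic carbon would read with a different amide group, since compound 2 gives only a limit, > 100000 nM, in this assay.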